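Swapping a Fluorophenyl for a Chlorophenyl

The compounds below may be only part of what the source reports. "The series", "measured", "known", "first", "only" and "open" are said of these compounds alone.

Measured so far:
compound 1 `CN(C)CCNc1nc(-c2ccc(NC(=O)Nc3ccccc3)cc2)nc2ccsc12`: 640 nM
compound 2 `CN(C)CCNc1nc(-c2ccc(NC(=O)Nc3ccc(F)cc3)cc2)nc2ccsc12`: 390 nM
compound 3 `CN(C)CCNc1nc(-c2ccc(NC(=O)Nc3ccccc3F)cc2)nc2ccsc12`: 410 nM

In a functional assay on NCI-H460 cells (Homo sapiens) for cytotoxicity, read by MTT assay, with a stated time of 72 h (a higher number here means a weaker inhibitor, a lower number a stronger inhibitor), compound 3 stands second highest of the three numbers, though all three sit close together: a 1.1-fold higher number from compound 2 to compound 3 (0.02 log units; within the scatter), and a 1.6-fold lower number from compound 1 to compound 3 (0.19 log units; within the scatter). The next compound to consider is compound 4 `CN(C)CCNc1nc(-c2ccc(NC(=O)Nc3ccc(Cl)cc3)cc2)nc2ccsc12`, and the change is 4-chlorophenyl in place of 2-fluorophenyl on an amide-type nitrogen. For the measured compounds named here, two measured steps bear on it. Adding a fluorine gave a 1.6-fold lower number from compound 1 to compound 2 (0.22 log units; within the scatter), and changing which fluorophenyl sits there gave a 1.1-fold higher number from compound 2 to compound 3 (0.02 log units; within the scatter), both within the scatter. Compound 4 carries a 4-chlorophenyl where compound 2 carries a 4-fluorophenyl, and in this assay compound 2 gives 390 nM. Nothing measured here shows a halogen change moving the number beyond the scatter, so for compound 4 the expected step is a 1.2-fold lower number from compound 3 to compound 4 (0.07 log units; within the scatter). The estimate for compound 4 is 350 nM, with a range from 150 nM to 800 nM.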

Compound 4, half-maximal inhibitory concentration: 130 nM
For compound 4 the middle estimate is 2.7-fold (0.43 log units) above the measured one, outside the stated range (below it).
By their numbers in this assay, from the lowest: compound 4; then compounds 2, 3 and 1 (each within the scatter of the next).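

In this assay, for the compounds shown here, the choice of halogen on this ring turns out to matter: chloro in place of fluoro gives a 3.0-fold lower number from compound 2 to compound 4 (0.48 log units; beyond the scatter) and is the first change here to go beyond the scatter. The other two comparisons agree, with a 3.2-fold lower number from compound 3 to compound 4 (0.50 log units; beyond the scatter) for 4-chlorophenyl in place of 2-fluorophenyl and a 4.9-fold lower number from compound 1 to compound 4 (0.69 log units; beyond the scatter) for chloro in place of hydrogen, so compound 4 has the lowest number of the four. Nothing available explains why chlorine behaves differently from fluorine here.

Still open, on these data alone, is whether 2-chlorophenyl would match 4-chlorophenyl, and whether 4-bromophenyl or 4-methylphenyl would lower the number further.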